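This account rests on a few compounds, and the source may have more. Where it says the series, first, only, none or still open, it means among the compounds named here.

Measured so far in an ADME assay (liver) for metabolic stability, with Liver microsome (Homo sapiens) as the target, read by LC-MS, using microsomes, with a stated time of 1 h, tested at 5 uM; on this read-out lower numbers stand for a less stable compound and higher numbers for a more stable compound:
- compound 1 (`Cc1nc(-c2ccccc2)c(C(=O)N2CCN(c3cccc(Cl)c3)CC2)o1`) gives 13.5%
- compound 2 (`Cc1nc(-c2ccc(F)cc2)c(C(=O)N2CCN(c3cc(Cl)cc(Cl)c3)CC2)o1`) gives 71.8%

Compound 2 holds the highest of the two numbers, and compound 1 lies lower by a gap beyond the scatter. Within the data shown here, the two compounds differ in more than one place, so no single-change step has been measured.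

Next is compound 3 (`COc1cc(OC)cc(N2CCN(C(=O)c3oc(C)nc3-c3ccc(F)cc3)CC2)c1`), which differs from compound 2 in one place (3,5-dimethoxyphenyl in place of 3,5-dichlorophenyl on an amine nitrogen in a ring). Here 3,5-dimethoxyphenyl stands in place of 3,5-dichlorophenyl on an amine nitrogen in a ring.

Among the measured compounds shown here, with no measured step for this change, its size in this assay is a judgement. A fall beyond the scatter is expected, with wide uncertainty. Compound 2 at 71.8% is the only high reading, and compound 1 at 13.5% shows that a much lower reading occurs among these close relatives. The estimated change is a number 33.8 percentage points lower from compound 2 to compound 3 (beyond the scatter) as the expected step. Compound 3 is expected at 38% (estimated range 14% to 66%).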

Compound 3, percent of the compound remaining: 12.9%
Compound 3: the middle estimate sits 25.1 percentage points above what was measured; measured number below the stated range.
By their numbers in this assay, from the lowest: compounds 3 and 1 (each within the scatter of the next); then compound 2.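

In this assay, among these compounds, this is the first single-change step, and it falls on the group carried on an amine nitrogen in a ring: a number 58.9 percentage points lower from compound 2 to compound 3 (beyond the scatter), with 3,5-dimethoxyphenyl in place of 3,5-dichlorophenyl. The position is therefore not indifferent in this read-out, since this exchange alone, with the rest of compound 2 unchanged, gives a large step; the entering group carries hydrogen-bond acceptors and the leaving group carries none. No measurement in hand bears on the reason for the size of this step.

The compounds shown leave open whether the step follows from the arrival of the methoxy groups or from the departure of the chlorine atoms, a question that a 3,5-difluorophenyl or 3,5-dimethylphenyl group at the same place could help to separate. Also open, as far as these compounds go, is whether a single methoxy group gives a step of similar size, and whether the same exchange has the same effect when the rest of the molecule differs.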